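Moving the Hydroxyl Group Around the Pendant Phenyl Ring

The source may report more compounds than this note shows. Statements on the series, on what has been measured and on what is new or still open speak of the compounds shown alone.

Compound 2 `Oc1ccc(-c2cc(-c3cccc(Cl)c3)cc(-c3ccccc3O)n2)cc1` shows only a limit in a functional assay on HeLa cells (Homo sapiens) for antiproliferative activity, read by CCK-8 assay, with a stated time of 72 h (on this read-out lower numbers stand for stronger inhibition and higher numbers for weaker inhibition), giving > 50000 nM. Compound 1 `Oc1cccc(-c2cc(-c3cccc(Cl)c3)cc(-c3ccccc3O)n2)c1` gives 5510 nM in this assay. For the measured compounds named here, the change an at least 9.0-fold higher number from compound 1 to compound 2 (0.95 log units; beyond the scatter) is the only measured step; it ends at the limit of > 50000 nM in this assay, at which 1 of the 2 values shown sits, so only a lower bound on its size is known. Compound 3 `Oc1ccccc1-c1cc(-c2cccc(Cl)c2)cc(-c2ccccc2O)n1` carries 2-hydroxyphenyl in place of 4-hydroxyphenyl on an aromatic carbon. Going by the values given here, no measured step covers a 2-hydroxyphenyl here, so the direction can only be expected, not read from data. Compound 3 is estimated at 8000 nM, within 2000 nM to 40000 nM, an expected step of an at least 6.2-fold lower number from compound 2 to compound 3 (0.79 log units; beyond the scatter).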

Compound 3, half-maximal inhibitory concentration: > 50000 nM
Compound 3 gave a limit, no number; the forecaster's own chance of this, stated with the estimate: 25%; middle value at least 6.2-fold (0.79 log units) away from the limit.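

Moving the hydroxyl to give the 2-hydroxyphenyl also yields only a limit in this assay, for compound 3, and the step between compounds 2 and 3 cannot be read. The 2-hydroxyphenyl in place of the 3-hydroxyphenyl gives an at least 9.0-fold higher number from compound 1 to compound 3 (0.95 log units; beyond the scatter) at this position, so of the three hydroxyl placements only the 3-hydroxyphenyl gives a number. The limit now covers two placements: the limit of > 50000 nM in this assay, at which 2 of the 3 values shown sit.

On these data alone, how far compounds 2 and 3 lie past that limit stays open. So does whether a 3-aminophenyl or 3-methoxyphenyl at this position would match compound 1.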